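Shrinking the saturated ring on the amide of compound 3

A few compounds are considered here, and "the series" means these few. Any claim that something is new, unique, unknown or untested is made for them only; others in the source may bear on it.

Compound 1 `COc1ccccc1C(=O)Nc1cccc(NC(=O)c2ccccc2Cl)c1` gives > 30000 nM in an in vitro functional assay on HEK293-A cells for antagonist activity at metabotropic glutamate receptor 5 (Rattus norvegicus), read by calcium flux; a higher number here means a weaker inhibitor, a lower number a stronger inhibitor; this is a limit of the assay, not a number.
Compound 2 `COc1ccccc1C(=O)Nc1cccc(NC(=O)c2cccc(C#N)c2)c1` gives 1800 nM in this assay.
Compound 3 `COc1ccccc1C(=O)Nc1cccc(NC(=O)C2CCCCC2)c1` gives > 30000 nM in this assay; this too is a limit, not a number.

Compound 3 therefore stands at the limit of > 30000 nM in this assay, at which 2 of the 3 values shown sit, together with compound 1, while compound 2 is the only one of the three with a measured number. The step of an at least 16-fold higher number from compound 2 to compound 3 (1.22 log units; beyond the scatter) is large, and the step that the two limits leave unreadable from compound 1 to compound 3 cannot be read from the two limits.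

Compound 4 `COc1ccccc1C(=O)Nc1cccc(NC(=O)C2CCC2)c1` differs from compound 3 only in this: cyclobutyl in place of cyclohexyl on a carbonyl carbon. Among the measured compounds shown here, no measured step changes the size of a saturated ring on that carbonyl carbon, so none bears on this change directly. What the measurements do show is that the cyclohexyl amide of compound 3 sits at the limit, and that the step of an at least 16-fold higher number from compound 2 to compound 3 (1.22 log units; beyond the scatter) was large. A smaller saturated ring is expected to leave compound 4 in the same region, and the step that the limit leaves unreadable from compound 3 to compound 4 is estimated to be none beyond the scatter. Compound 4 is expected to give about 40000 nM in this assay, within 12000 nM to 150000 nM, most likely reported again as a limit.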

Compound 4, half-maximal inhibitory concentration: > 30000 nM
Compound 4: no number, only a limit (the forecaster's own chance of this, stated with the estimate: 80%); the middle value lies beyond the limit too.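

Among the compounds shown here, compound 4 joins compound 3 at the limit in this assay, so on this carbonyl carbon the four-membered saturated ring ends up in the same place as the six-membered one, and changing the ring size has not yet brought a measurable number: the limit of > 30000 nM in this assay, at which 3 of the 4 values shown sit. The move from the 3-cyanophenyl group to cyclobutyl gives an at least 16-fold higher number from compound 2 to compound 4 (1.22 log units; beyond the scatter), which leaves 3-cyanophenyl as the only group here with a measured value, although 2-chlorophenyl in compound 1 shows that an aromatic ring alone does not guarantee one. The steps from compound 3 to compound 4 and from compound 1 to compound 4 join two limits and cannot be read, so any true difference among these three compounds stays hidden.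

On these data alone, it remains open whether a saturated ring on this carbonyl carbon can give a measured number at all, for example a cyclohexyl ring carrying a nitrile, or a piperidine ring with its amine. Also open, as far as these compounds go, is whether the nitrile itself matters, which an unsubstituted phenyl ring or a 3-methoxyphenyl ring in the same place could begin to show.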